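Swapping a Saturated Ring for an Aromatic One

The compounds below may be only part of what the source reports. "The series", "measured", "known", "first", "only" and "open" are said of these compounds alone.

Among the compounds with values here, compound 3 `Cc1cc(N2CCC(N)CC2)c(S(C)(=O)=O)cc1C(=O)N=C(N)N` gives 9.8 nM in a functional assay for inhibition of sodium/hydrogen exchanger (Oryctolagus cuniculus) (a lower number here means a stronger inhibitor, a higher number a weaker inhibitor), the second highest of the three numbers measured so far, with compound 1 `Cc1cc(C)c(S(C)(=O)=O)cc1C(=O)N=C(N)N` at 11 nM and compound 2 `Cc1cc(C2CCC2)c(S(C)(=O)=O)cc1C(=O)N=C(N)N` at 8.2 nM; all three sit within the scatter of one another. Compound 4 `Cc1cc(-n2ccnc2C)c(S(C)(=O)=O)cc1C(=O)N=C(N)N` differs from compound 3 by 2-methyl-1H-imidazol-1-yl in place of 4-aminopiperidin-1-yl on an aromatic carbon. Within the data shown here, two measured steps concern the same position: a 1.1-fold lower number from compound 1 to compound 3 (0.05 log units; within the scatter) and a 1.2-fold higher number from compound 2 to compound 3 (0.08 log units; within the scatter), both within the scatter. Three rather different groups at this position have left the number essentially where it was, so a fourth group is expected to do the same. The step of a 1.0-fold higher number from compound 3 to compound 4 (0.01 log units; within the scatter) is therefore expected to stay within the scatter. Compound 4 is estimated at 10 nM, with a likely range from 4 nM to 25 nM.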

Compound 4, half-maximal inhibitory concentration: 29 nM
The estimate for compound 4 lay 2.9-fold (0.46 log units) below the measured number; the whole stated range lies below it.
By their numbers in this assay, from the lowest: compounds 2, 3 and 1 (each within the scatter of the next); then compound 4.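

The position does respond to its group after all: there is a 3.0-fold higher number from compound 3 to compound 4 (0.47 log units; beyond the scatter) and a 3.5-fold higher number from compound 2 to compound 4 (0.55 log units; beyond the scatter) and also a 2.6-fold higher number from compound 1 to compound 4 (0.42 log units; beyond the scatter). Among these four compounds, 2-methyl-1H-imidazol-1-yl is the only group that moves the number, and compound 4 is the weakest inhibitor. Nothing available explains this rise.

As far as these compounds go, whether the rise belongs to the aromatic ring or to its methyl group remains open. A plain 1H-imidazol-1-yl group, without the methyl, would help to separate the two.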